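Cytotoxicity notes: the step from compound 3 to compound 4

The compounds below may be only part of what the source reports. "The series", "measured", "known", "first", "only" and "open" are said of these compounds alone.

Three compounds of the shared core have so far been run in an ADME assay on HEK293 cells (Homo sapiens) for cytotoxicity, read by ATP content, with a stated time of 6 h; a lower number here means that less compound is tolerated, a higher number that more compound is tolerated. Compound 1 `CCCCNc1nc(N)nc2ccn(Cc3ccc4ccccc4n3)c12` returns only the limit > 24000 nM and no number. Compound 2 `CCCCNc1nc(N)nc2ccn(Cc3ncccc3OC)c12` likewise returns the limit > 24000 nM rather than a number. Compound 3 `COCCNc1nc(N)nc2ccn(Cc3ccccn3)c12` also comes back at the limit > 24000 nM with no number behind it. Compound 3 therefore stands with the other two at the limit of > 24000 nM in this assay, at which 3 of the 3 values shown sit; nothing in the measured numbers separates the three.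

Among the compounds with values here, no step between measured compounds is available. Compound 4 `CC(C)c1cc(CNc2nc(N)nc3ccn(Cc4ccccn4)c23)no1` differs from compound 3 in one place: 5-isopropyl-1,2-oxazol-3-yl in place of methoxymethyl on a saturated chain carbon bound to a nitrogen on an aromatic ring. Within the data shown here, with every measured value resting at the limit, there is no measured step from which to read a direction for this change. The expected step from compound 3 to compound 4 in this assay is a number no higher from compound 3 to compound 4 (the limit leaves the size open), that is, none beyond the scatter. Compound 4 is accordingly estimated at about 24000 nM, within a range of 8000 nM to 60000 nM, and the assay is expected most likely to report only the limit again.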

Compound 4, half-maximal cytotoxic concentration: > 24000 nM
Compound 4: no number, only a limit (the forecaster's own chance of this, stated with the estimate: 70%); the middle value lies on the limit itself.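

Compound 3 and compound 4 both return only a limit in this assay, so no step can be read between them. The compounds shown leave open whether any change on the shared core moves the half-maximal cytotoxic concentration at all, with every value resting at one mark: the limit of > 24000 nM in this assay, at which 4 of the 4 values shown sit.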